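This account rests on a few compounds, and the source may have more. Where it says the series, first, only, none or still open, it means among the compounds named here.

Measured compounds:
compound 1 `N#Cc1cccc(C(=O)Nc2ccc3nc(NC(=O)C4CCCCC4)sc3c2)c1` — 0.52 ug/mL
compound 2 `CCCC(=O)Nc1nc2ccc(NC(=O)c3c(Cl)cccc3Cl)cc2s1` — 0.01 ug/mL

In a functional assay on WI-38 VA13 cells (Homo sapiens) for cytotoxicity (a lower number here means that less compound is needed, a higher number that more compound is needed for the effect), compound 2 gives 0.01 ug/mL, the lowest of the two numbers shown. Compound 1 gives 0.52 ug/mL in this assay, a gap that lies well beyond the scatter, but the two structures differ in more than one place, so no single step can be read from the pair.

Compound 3 `COC(=O)Nc1nc2ccc(NC(=O)c3c(Cl)cccc3Cl)cc2s1` differs from compound 2 in one place: methoxy in place of propyl on a carbonyl carbon. Among the measured compounds shown here, no step between measured compounds covers a change of this kind, so the expectation rests on compound 2 alone. The step of a 3.0-fold higher number from compound 2 to compound 3 (0.48 log units; beyond the scatter) is expected to be small and towards a higher number, possibly not beyond the scatter. Compound 3 is estimated at 0.03 ug/mL, with a range from 0.008 ug/mL to 0.12 ug/mL, the result of which is awaited.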

Compound 3, half-maximal effective concentration: 0.0095 ug/mL
Estimate against measurement, compound 3: 3.2-fold (0.50 log units) above; the measured number falls inside the stated range.
By their numbers in this assay, from the lowest: compounds 3 and 2 (each within the scatter of the next); then compound 1.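

In this assay, methoxy in place of propyl on a carbonyl carbon gives a 1.1-fold lower number from compound 2 to compound 3 (0.02 log units; within the scatter), so compound 2 and compound 3 stand level and the two groups cannot be told apart at this position. The earlier pair could not show this: the first single-place comparison indicates that this carbonyl carbon can carry either propyl or methoxy with no readable difference, a finding that rests on these two groups on this core alone. Nothing available bears on the reason for this result.

Going by these compounds, whether a longer chain, a dimethylamino group or a phenyl ring on the same carbonyl carbon would also stand level remains open. Compound 1 differs from compound 2 in more than one place, so its gap cannot be assigned to any single difference.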